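The compounds below may be only part of what the source reports. "The series", "measured", "known", "first", "only" and "open" are said of these compounds alone.

Measured in a functional assay on MGC-803 cells (Homo sapiens) for inhibition, read by MTT assay, with a stated time of 72 h; a higher number here means a weaker inhibitor, a lower number a stronger inhibitor:
- Compound 1 `Cc1cc(N2CC[C@@H](C)[C@@H](N(C)c3ncnc4[nH]ccc34)C2)n2nc(SCc3nc4ccccc4[nH]3)nc2n1`: 21200 nM
- Compound 2 `Cc1nc2nc(SCc3ccc(Cl)cc3)nn2c(N2CC[C@@H](C)[C@@H](N(C)c3ncnc4[nH]ccc34)C2)c1C`: 90500 nM
- Compound 3 `CCCCCc1c(C)nc2nc(SCc3ccc(Cl)cc3)nn2c1N1CC[C@@H](C)[C@@H](N(C)c2ncnc3[nH]ccc23)C1`: > 100000 nM, which is a limit of the assay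

Compound 1 has the lowest number shown, and compound 2 lies beyond the scatter above it. Compound 4 `Cc1ccc(CSc2nc3nc(C)cc(N4CC[C@@H](C)[C@@H](N(C)c5ncnc6[nH]ccc56)C4)n3n2)cc1` follows from compound 1 by one change, 4-methylphenyl in place of 1H-benzimidazol-2-yl on a saturated chain carbon bound to a sulfur. Going by the values given here, the only measured step, an at least 1.1-fold higher number from compound 2 to compound 3 (0.04 log units; that floor lies within the scatter), lies at another place and gives no size for this change. The closest guide is compound 2, which also lacks 1H-benzimidazol-2-yl, at 90500 nM. The estimated step, towards a higher number, is a 2.1-fold higher number from compound 1 to compound 4 (0.33 log units; beyond the scatter). For compound 4 the expected value is 45000 nM, with an estimated range of 16000 nM to 100000 nM.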

Compound 4, half-maximal inhibitory concentration: 5860 nM
Beside the measured number, compound 4's estimate is 7.7-fold (0.89 log units) above it; the measured number lies below the stated range.
By their numbers in this assay, from the lowest: compound 4; then compound 1; then compound 2. At a limit, above all of these: compound 3.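

In this assay, the group on the saturated chain carbon bound to a sulfur clearly affects the result: a 3.6-fold lower number from compound 1 to compound 4 (0.56 log units; beyond the scatter). A lower number is therefore reached here with 4-methylphenyl, which has no hydrogen-bond donor or acceptor, so the donor and acceptor of 1H-benzimidazol-2-yl are not required for activity at this level. Nothing measured in this set gives a cause for the step.

Still open, as far as these compounds go, is whether the methyl of 4-methylphenyl contributes to the step. Unsubstituted phenyl, or an amine or a carboxylic acid on that ring, would test this.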